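This account rests on a few compounds, and the source may have more. Where it says the series, first, only, none or still open, it means among the compounds named here.

In a functional assay on the whole organism for agonist activity, with Mus musculus as the target (a lower number here means that less compound is needed, a higher number that more compound is needed for the effect), compound 1 `CC(=O)N(C)C(C)C#CCn1ccnc1` gives 2 mg/kg and compound 3 `CC1CCC(=O)N1CC#CCN(C)C` gives 1.7 mg/kg. Compound 2 `CC(=O)N(C)C(C)C#CCn1cncc1C` gives > 100 mg/kg, which is a limit and not a number. Compound 4 `CC(=O)N(C)CC#CCn1cncc1C` differs from compound 2 by hydrogen in place of methyl on a saturated chain carbon bound to an amide-type nitrogen and a triple-bonded carbon, with hydrogen in place of methyl on a saturated chain carbon bound to an amide-type nitrogen and a triple-bonded carbon. For the measured compounds named here, the one measured step that bears on this is large, an at least 50-fold higher number from compound 1 to compound 2 (1.69 log units; beyond the scatter), and it comes with methyl in place of hydrogen on an aromatic carbon. Going by the values given here, compound 4 keeps that methyl, and no measured step covers the chain methyl alone. In this assay the expected step is a number no higher from compound 2 to compound 4 (the limit leaves the size open), with no change beyond the scatter anticipated. Compound 4 is estimated at 100 mg/kg, with an expected range of 20 mg/kg to 300 mg/kg.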

Compound 4, dose for half-maximal effect: 5.4 mg/kg
The estimate for compound 4 lay 19-fold (1.27 log units) above the measured number; the measured number lies below the stated range.
By their numbers in this assay, from the lowest: compounds 3 and 1 (each within the scatter of the next); then compound 4. At a limit, above all of these: compound 2.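

In this assay, for the compounds shown here, hydrogen in place of methyl on the saturated chain carbon bound to an amide-type nitrogen and a triple-bonded carbon gives an at least 18-fold lower number from compound 2 to compound 4 (1.26 log units; beyond the scatter), so this position matters, which the earlier compounds did not show. Compound 4 keeps the methyl on the aromatic carbon, so that methyl alone does not bring a compound to the limit. The size of the step stays open-ended, since the value of compound 2 is a limit and not a number: the limit of > 100 mg/kg in this assay, at which 1 of the 4 values shown sits.

The compounds shown leave open what the chain methyl does when the aromatic carbon carries hydrogen. They also leave open how an ethyl group at the chain carbon would compare.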